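A Trifluoromethyl Group Added to a Fluorophenyl Ring

The compounds below may be only part of what the source reports. "The series", "measured", "known", "first", "only" and "open" are said of these compounds alone.

Compound 1 `CC1=C(/C=C/C(=O)/C=C/c2cccc(F)c2)C(C)(C)CCC1O` and compound 2 `CC1=C(/C=C/C(=O)/C=C/c2ccc(F)cc2)C(C)(C)CCC1O` share one core; the difference between them is 3-fluorophenyl in place of 4-fluorophenyl on a double-bonded chain carbon bound to a double-bonded chain carbon. In a functional assay on CWR22R cells (Homo sapiens) for cytotoxicity, read by MTT assay, with a stated time of 72 h (on this read-out higher numbers stand for weaker inhibition and lower numbers for stronger inhibition), compound 1 gives 5600 nM, and compound 2 gives 7500 nM, so that a 1.3-fold higher number from compound 1 to compound 2 (0.13 log units; within the scatter). Compound 3 `CC1=C(/C=C/C(=O)/C=C/c2ccc(F)c(C(F)(F)F)c2)C(C)(C)CCC1O` differs from compound 2 by trifluoromethyl in place of hydrogen on an aromatic carbon. In this assay compound 3 gives 3200 nM, which means a 2.3-fold lower number from compound 2 to compound 3 (0.37 log units; beyond the scatter). Compound 4 `CC1=C(/C=C/C(=O)/C=C/c2cc(F)cc(C(F)(F)F)c2)C(C)(C)CCC1O` has not yet been measured in this assay. It differs from compound 1 by trifluoromethyl in place of hydrogen on an aromatic carbon. Within the data shown here, this is the same kind of change as the one from compound 2 to compound 3, but not the same: in compound 3 the entering trifluoromethyl sits ortho to a fluoro group, whereas in compound 4 it sits meta to a fluoro group. Because the earlier step was a 2.3-fold lower number from compound 2 to compound 3 (0.37 log units; beyond the scatter), a step of similar size is expected here: a 2.0-fold lower number from compound 1 to compound 4 (0.30 log units; within the scatter). Compound 4 is therefore estimated at 2800 nM, with the likely range running from 1400 nM to 6000 nM.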

Compound 4, half-maximal inhibitory concentration: 2400 nM
Compound 4: middle estimate off by 1.2-fold (0.07 log units), on the high side; measured number inside the range.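

In this assay, trifluoromethyl in place of hydrogen on an aromatic carbon gives a 2.3-fold lower number from compound 1 to compound 4 (0.37 log units; beyond the scatter). Set beside the earlier step, this shows that the change carried over from one fluorophenyl compound to the other with no difference in size beyond what repeated measurements would produce: the same change on two cores in this assay, a 2.3-fold lower number (0.37 log units; beyond the scatter) from compound 2 to compound 3 and a 2.3-fold lower number (0.37 log units; beyond the scatter) from compound 1 to compound 4, 1.0-fold (0.00 log units) apart, within the scatter of two such steps This is only two pairs in a single cell assay, both with a fluoro group already on the aromatic ring, so it does not show that the step would keep its size on other cores, and it says nothing about why the numbers fall.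

Going by these compounds, it remains open whether a chlorine atom, a methyl group or a nitrile in the place of trifluoromethyl would lower the number by a similar amount. The compounds shown also leave open what the same change would do on an aromatic ring without a fluoro group, or on a core whose hydroxyl is replaced by an amine.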